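The compounds below may be only part of what the source reports. "The series", "measured", "known", "first", "only" and "open" are said of these compounds alone.

Compound 1 `CC(CSc1cc(C(F)(F)F)cc(C(F)(F)F)c1)C(=O)Nc1ccc(C#N)cc1C(F)(F)F` and compound 2 `CC(CSc1cc(C(F)(F)F)cc(C(F)(F)F)c1)C(=O)Nc1ccc([N+](=O)[O-])cc1C(F)(F)F` share one core and differ at a single ring position: nitro in place of cyano on an aromatic carbon. In a functional assay on LNCaP cells (Homo sapiens) for antiproliferative activity, read by MTT assay, with a stated time of 96 h (a lower number here means a stronger inhibitor, a higher number a weaker inhibitor), compound 1 gives 4570 nM, while compound 2 gives 43700 nM, so that a 9.6-fold higher number from compound 1 to compound 2 (0.98 log units; beyond the scatter). Compound 3 `CC(CS(=O)(=O)c1ccc(F)cc1)C(=O)Nc1ccc(C#N)c(C(F)(F)F)c1` is built on another core; the difference between the two cores is not broken down here. In this assay compound 3 gives 115000 nM, the highest of the three numbers. Compound 4 `CC(CS(=O)(=O)c1ccc(F)cc1)C(=O)Nc1ccc([N+](=O)[O-])c(C(F)(F)F)c1` is not yet measured and carries the same kind of change as compound 2: nitro in place of cyano on an aromatic carbon. The surroundings differ, though: in compound 4 the nitro sits ortho to the trifluoromethyl group, in compound 2 meta to it. Because a 9.6-fold higher number from compound 1 to compound 2 (0.98 log units; beyond the scatter), the expected step for compound 4 is a 4.3-fold higher number from compound 3 to compound 4 (0.64 log units; beyond the scatter). Compound 4 is therefore expected to give about 500000 nM, with a plausible range from 150000 nM to 1500000 nM.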

Compound 4, half-maximal inhibitory concentration: 2670 nM
For compound 4 the middle estimate is 190-fold (2.27 log units) above the measured one; the whole stated range lies above it.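

In this assay the change from cyano to nitro gives a 43-fold lower number from compound 3 to compound 4 (1.63 log units; beyond the scatter), so on this core nitro is the better group, the opposite of what was seen on the core of compound 1. Carried from one core to the other, this change keeps neither its direction nor its size: the same change on two cores in this assay, a 9.6-fold higher number (0.98 log units; beyond the scatter) from compound 1 to compound 2 and a 43-fold lower number (1.63 log units; beyond the scatter) from compound 3 to compound 4, 410-fold (2.61 log units) apart, beyond the scatter of two such steps The two cores differ in more than one place, and two pairs cannot show which of those differences matters, or which way the change would go on a third core.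

Going by these compounds, it remains open how other groups at this ring position, such as an amine or a carboxylic acid, would compare with cyano and nitro on either core. On these data alone, whether the reversal holds in other cell lines also stays open.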